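The source may report more compounds than this note shows. Statements on the series, on what has been measured and on what is new or still open speak of the compounds shown alone.

Compound 1 `O=C1Nc2ccc(C(=O)c3ccco3)cc2/C1=C/c1ccc(O)c(Br)c1` gives 23% in an assay on HeLa cells for inhibition of Kinesin-like protein KIF15 (Homo sapiens), read by microscopy, with stated times of 2 s and 20 s, tested at 750 nM; a lower number here means less inhibition, a higher number more inhibition at the concentration tested (going by the name of the read-out). Compound 2 `O=C1Nc2ccc(C(=O)N3CCCC3)cc2/C1=C/c1cc(Cl)c(O)c(Cl)c1` gives -10% in this assay.

Of these two, compound 2 stands lowest in this assay; the value of compound 1 lies above it by more than the usual scatter. Compound 3 `O=C1Nc2ccc(-c3ccco3)cc2/C1=C/c1cc(Cl)c(O)c(Cl)c1` is the next step: furan-2-yl in place of (pyrrolidin-1-yl)carbonyl on an aromatic carbon. For the measured compounds named here, no measured pair shows this exact change, so the expectation leans only on compound 1, which also carries a furan ring and gives 23%. A modest rise, just beyond the scatter, is expected, a number 18 percentage points higher from compound 2 to compound 3 (beyond the scatter). Compound 3 is therefore estimated at 8%, within -15% to 32%.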

Compound 3, a percentage reported as inhibition, at one concentration (the size of the read-out at that concentration, not a potency): 33%
Beside the measured number, compound 3's estimate is 25 percentage points below it; the whole stated range lies below it.
By their numbers in this assay, from the lowest: compound 2; then compounds 1 and 3 (each within the scatter of the next).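

On this aromatic carbon of the shared core, the choice of group clearly matters: in this assay, furan-2-yl in place of (pyrrolidin-1-yl)carbonyl gives a number 43 percentage points higher from compound 2 to compound 3 (beyond the scatter). For the compounds shown here, this is the first pair differing in only one place, so it is the first direct sign that a change here can move the read-out. Nothing measured here explains the step.

Going by these compounds, whether a phenyl ring, a thiophene ring or a simple amine at this position would give a similar result remains open. So does whether the step would hold with different groups elsewhere on the core.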